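A few compounds are considered here, and "the series" means these few. Any claim that something is new, unique, unknown or untested is made for them only; others in the source may bear on it.

Of the compounds shown here, three have so far been measured in a functional assay on HeLa cells (Homo sapiens) for cytotoxicity, read by MTT assay, with a stated time of 72 h, tested at 3 uM; a lower number here means less inhibition of growth, a higher number more inhibition of growth at the concentration tested. Compound 1 `Cc1ccnc(/C(N)=N/NC(=S)N2CCOCC2)c1` gives 44.7%. Compound 2 `N/C(=N\NC(=S)N1CCCC1)c1ccc(F)cn1` gives 77.7%, the highest of the three numbers, standing beyond the scatter above both of the others. Compound 3 `N/C(=N\NC(=S)N1CCOCC1)c1ccc(F)cn1` gives 59.7%. Within the data shown here, the only pair that differs in a single place shows a modest drop, a number 18 percentage points lower from compound 2 to compound 3 (beyond the scatter), with morpholin-4-yl in place of pyrrolidin-1-yl on the thiocarbonyl carbon.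

Compound 4 `N/C(=N\NC(=S)N1CCCC1)c1ccccn1` has not yet been measured. It differs from compound 2 by hydrogen in place of fluoro on an aromatic carbon. Among the measured compounds shown here, no measured step touches this part of the molecule: the one step at hand, from compound 2 to compound 3, concerns the ring on the thiocarbonyl carbon and so offers no direct guide to what removing the fluoro does. Starting from compound 2, a small change or none beyond the scatter is therefore expected, written as the estimated step of a number 12.7 percentage points lower from compound 2 to compound 4 (beyond the scatter). Compound 4 is expected to give about 65%, within a range from 45% to 85%.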

Compound 4, percent growth inhibition at one concentration: 38.5%
For compound 4 the middle estimate is 26.5 percentage points above the measured one, outside the stated range (below it).
By their numbers in this assay, from the lowest: compounds 4 and 1 (each within the scatter of the next); then compound 3; then compound 2.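

In this assay, the fluoro group on the aromatic ring, two atoms from the ring nitrogen and para to a large group, proves to matter a great deal: hydrogen in its place gives a number 39.2 percentage points lower from compound 2 to compound 4 (beyond the scatter), a large step. The loss of this single atom thus counts for more than the modest step seen on the thiocarbonyl carbon, a number 18 percentage points lower from compound 2 to compound 3 (beyond the scatter), so this aromatic position is the more sensitive of the two places compared so far. Nothing available explains why removing one fluorine atom changes the number so much.

As far as these compounds go, what a chloro, methyl or methoxy group at this position would give remains open. So does whether hydrogen in place of fluoro would cost as much with morpholin-4-yl on the thiocarbonyl carbon as it does with pyrrolidin-1-yl.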